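Replacing the nitrogen substituent of compound 3

This account rests on a few compounds, and the source may have more. Where it says the series, first, only, none or still open, it means among the compounds named here.

Measured in a functional assay on A549 cells (Homo sapiens) for cytotoxicity, read by resazurin assay, with a stated time of 72 h; a higher number here means a weaker inhibitor, a lower number a stronger inhibitor:
- compound 1 `N#Cc1cc(-c2ccccc2)n(-c2ccccn2)c1N`: 32000 nM
- compound 2 `N#Cc1cc(-c2ccccc2)n(-c2cccc(Br)c2)c1N`: 13000 nM
- compound 3 `Nc1c(-c2nc3ccccc3[nH]2)cc(-c2ccccc2)n1-c1ccccn1`: 8000 nM

Compound 3 sits within the usual scatter of compound 2 and is clearly separated from compound 1, with a 4.0-fold lower number from compound 1 to compound 3 (0.60 log units; beyond the scatter). In compound 4 `Nc1c(-c2nc3ccccc3[nH]2)cc(-c2ccccc2)n1Cc1nc2ccccc2[nH]1`, (1H-benzimidazol-2-yl)methyl stands in place of pyridin-2-yl on an aromatic nitrogen: (1H-benzimidazol-2-yl)methyl in place of pyridin-2-yl on an aromatic nitrogen. For the measured compounds named here, two measured steps bear on this change. The only earlier change on that nitrogen gave a 2.5-fold lower number from compound 1 to compound 2 (0.39 log units; beyond the scatter), and 1H-benzimidazol-2-yl, which the new group contains, gave the modest step already shown. The expected result in this assay is another modest move towards a lower number, a 2.0-fold lower number from compound 3 to compound 4 (0.30 log units; within the scatter). Compound 4 is estimated at 4000 nM, with an expected range of 1000 nM to 13000 nM.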

Compound 4, half-maximal inhibitory concentration: 5100 nM
Beside the measured number, compound 4's estimate is 1.3-fold (0.11 log units) below it; low and high end bracket the measured number.
By their numbers in this assay, from the lowest: compounds 4, 3 and 2 (each within the scatter of the next, the first and the last beyond it); then compound 1.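

On the aromatic nitrogen, this assay shows a 1.6-fold lower number from compound 3 to compound 4 (0.20 log units; within the scatter) when (1H-benzimidazol-2-yl)methyl stands in place of pyridin-2-yl. So this position carries a larger group, joined through a carbon and bringing a hydrogen-bond donor, with no change beyond the scatter, whereas the earlier step on this nitrogen lay beyond it. No supporting evidence is available to explain this result. The compounds shown leave open how a simple benzyl group, which keeps the carbon link without the benzimidazole, would compare. An aminoethyl chain or a carboxylic acid on this nitrogen also remains an open question.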